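This account rests on a few compounds, and the source may have more. Where it says the series, first, only, none or still open, it means among the compounds named here.

Of the compounds shown here, three sharing one core have been measured in a physicochemical assay for solubility, read by HPLC, in phosphate buffer, at pH 6.5; on this read-out higher numbers stand for higher solubility and lower numbers for lower solubility. Compound 1 `COC(=O)C1=C(C)NC(c2nccs2)=NC1(C)c1ccc(F)cc1` gives 22 ug/mL, compound 2 `COC(=O)C1=C(C)NC(c2nccs2)=N[C@]1(C)c1ccc(F)cc1` gives 178 ug/mL, and compound 3 `COC(=O)C1=C(CN2CCNCC2)NC(c2nccs2)=NC1(C)c1ccc(F)cc1` gives 250 ug/mL. Compound 3 therefore stands level with compound 2 within the scatter, and both lie clearly apart from compound 1.

Compound 4 `COC(=O)C1=C(CN2CCOCC2=O)NC(c2nccs2)=NC1(C)c1ccc(F)cc1` has not yet been measured. It differs from compound 3 by carrying 3-oxomorpholin-4-yl in place of piperazin-1-yl on a saturated chain carbon bound to a double-bonded ring carbon.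

The most direct guide is the step that brought piperazin-1-yl onto this carbon in the first place, which gave an 11-fold higher number from compound 1 to compound 3 (1.06 log units; beyond the scatter). Compound 4 no longer carries that group, so part of this large rise may be lost, although its new ring may keep some of it. Among the measured compounds shown here, no measured compound carries 3-oxomorpholin-4-yl, so this remains uncertain. The other step, an 8.1-fold higher number from compound 1 to compound 2 (0.91 log units; beyond the scatter), bears on the change only as a warning. It involves no new atoms, only (the fact that one of compounds 1 and 2 is drawn with a defined configuration and the other without, at the place where they differ), yet it still lies beyond the scatter.

A moderate fall is expected in this assay, an estimated 3.6-fold lower number from compound 3 to compound 4 (0.55 log units; beyond the scatter). For compound 4 the estimated value is 70 ug/mL, with an expected range of 20 ug/mL to 220 ug/mL.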

Compound 4, solubility: 440 ug/mL
Compound 4: middle estimate off by 6.3-fold (0.80 log units), on the low side; the measured number lies above the stated range.
By their numbers in this assay, from the lowest: compound 1; then compounds 2, 3 and 4 (each within the scatter of the next, the first and the last beyond it).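

In this assay, putting 3-oxomorpholin-4-yl in place of piperazin-1-yl gives a 1.8-fold higher number from compound 3 to compound 4 (0.25 log units; within the scatter) on this saturated chain carbon, so the two groups cannot be told apart on this read-out. Measured against hydrogen at the same place, the new group gives a 20-fold higher number from compound 1 to compound 4 (1.30 log units; beyond the scatter) and so stands clearly apart from compound 1, as compound 3 does. The rise at this position is therefore not tied to piperazin-1-yl alone, since it also appears with a ring that has 0 hydrogen-bond donors rather than 1 and carries two oxygens where piperazin-1-yl has a second nitrogen.

Still open, going by these compounds, is whether a small open-chain amine such as dimethylamino, or a carboxylic acid, would read the same way on this carbon, and whether either ring would add anything to compound 2, given that a drawn configuration alone accounts for an 8.1-fold higher number from compound 1 to compound 2 (0.91 log units; beyond the scatter) with no new group at all. Nothing in the information available explains why these two different rings read alike.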